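Amide nitrogen substitution on the dimethoxy core: paw edema

The source may report more compounds than this note shows. Statements on the series, on what has been measured and on what is new or still open speak of the compounds shown alone.

Compound 1 `COc1cc2c(cc1OC)C(CC(N)=O)CC2` carries a primary amide on the shared core; in a functional assay on the whole organism (strain Wistar) for inhibition, with Rattus norvegicus as the target, read by paw edema, with stated times of 60 min and 4 h, at a dose of 100 mg/kg by the oral route (a lower number here means less inhibition, a higher number more inhibition at the dose given (going by the name of the read-out)), compound 1 gives 31.3%. Compound 2 `CCCCCNC(=O)CC1CCc2cc(OC)c(OC)cc21` has pentyl in place of hydrogen on that amide nitrogen, and in this assay compound 2 gives 40.6%. For the measured compounds named here, the single measured step is a number 9.3 percentage points higher from compound 1 to compound 2 (within the scatter), so the two numbers cannot be ordered against each other. Compound 2 holds the highest of the two numbers, with compound 1 nearest and within the scatter.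

Compound 3 `COc1cc2c(cc1OC)C(CC(=O)N1CCCCC1)CC2` is the next member, not yet measured in this assay. It differs from compound 2 in piperidin-1-yl in place of pentylamino on a carbonyl carbon. Going by the values given here, the only step that bears on this change is the one from compound 1 to compound 2, which also altered the substitution on the amide nitrogen and stayed within the scatter. Nothing measured addresses the closing of the nitrogen into a ring or the loss of the hydrogen-bond donor. The expectation for compound 3 is therefore no step beyond the scatter, a number 0.6 percentage points lower from compound 2 to compound 3 (within the scatter). The estimate for compound 3 in this assay is 40%, with a range from 25% to 55%.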

Compound 3, a percentage reported as inhibition, in the whole organism at one dose (the size of the read-out at that dose, not a potency): 32%
The estimate for compound 3 lay 8 percentage points above the measured number, within the range that was stated.
By their numbers in this assay, from the lowest: compounds 1, 3 and 2 (each within the scatter of the next).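

In this assay, replacing the open pentylamino chain with the piperidin-1-yl ring on the carbonyl carbon gives a small shift (a number 8.6 percentage points lower from compound 2 to compound 3 (within the scatter)), and the same ring in place of the amino of the primary amide gives another (a number 0.7 percentage points higher from compound 1 to compound 3 (within the scatter)). This position has now carried amino, pentylamino and piperidin-1-yl, the last of which has no hydrogen-bond donor, and no step among the three compounds stands clear of the scatter, so at this dose neither the ring nor the absence of that donor is shown to change the read-out. No measurement here offers an explanation of these numbers.

Still open, from the compounds shown here alone, is whether any group on this carbonyl carbon can move the number beyond the scatter, for example a carboxylic acid in place of the amide, a morpholin-4-yl ring in place of piperidin-1-yl, or a chain longer than pentylamino. Also open, going by these compounds, is whether the three compounds stay this close at other oral doses, or when the two methoxy groups on the shared core give way to other groups.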